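One ring group exchanged, from compound 3 to compound 4

The source may report more compounds than this note shows. Statements on the series, on what has been measured and on what is new or still open speak of the compounds shown alone.

Of the compounds shown here, three have been measured so far, and none gives a number. In a functional assay on NALM-6 cells (Homo sapiens) for cytotoxicity, with a stated time of 72 h (on this read-out higher numbers stand for an effect only at larger amounts of compound and lower numbers for an effect already at smaller amounts), compound 1 (`C=C[C@@](C)(/C=C/c1ccc(OS(=O)(=O)C(F)(F)F)cc1)CCC=C(C)C`) reads > 43400 nM, which is a limit of the assay. In this assay, compound 2 (`COc1ccc(/C=C/[C@@](C)(/C=C/c2ccc(O)c(C=O)c2)CCC=C(C)C)cc1`) reads > 43400 nM, again a limit. In this assay, compound 3 (`CCOc1ccc(/C=C/[C@@](C)(/C=C/c2ccc(O)cc2)CCC=C(C)C)cc1`) reads > 43400 nM, also a limit. Compound 3 therefore stands with the other two, and the whole set is summed up as the limit of > 43400 nM in this assay, at which 3 of the 3 values shown sit.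

Compound 4 (`CC(C)=CCC[C@](C)(/C=C/c1ccc(O)cc1)/C=C/c1cccc(F)c1`) differs from compound 3 in one place, with 3-fluorophenyl in place of 4-ethoxyphenyl on a double-bonded chain carbon bound to a double-bonded chain carbon. For the measured compounds named here, no measured pair shows what a single change does here, so little movement is expected, and none beyond the scatter. The expected step is an at least 1.0-fold lower number from compound 3 to compound 4 (0.03 log units; that floor lies within the scatter). Another reading that is only a limit would be no surprise. For compound 4 the estimated value is 40000 nM, with an expected range from 12000 nM to 80000 nM.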

Compound 4, half-maximal effective concentration: > 43400 nM
Compound 4: a limit, no number; the forecaster's own chance of this, stated with the estimate: 70%; at least 1.0-fold (0.03 log units) between middle value and limit.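

Compound 3 and compound 4 both give only a limit in this assay, so no step can be read from exchanging 4-ethoxyphenyl for 3-fluorophenyl. The compounds shown leave open what true value any of them has and which change would give a real number, as the whole set stands at one limit: the limit of > 43400 nM in this assay, at which 4 of the 4 values shown sit.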